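This account rests on a few compounds, and the source may have more. Where it says the series, first, only, none or still open, it means among the compounds named here.

In an in vitro functional assay on cells for agonist activity at Bombesin receptor subtype-3 (Homo sapiens), read by luminescence and calcium flux (a lower number here means that less compound is needed, a higher number that more compound is needed for the effect), compound 2 `O=C(O)c1ccccc1-c1ccc(CCc2ncc(CC3CC3)[nH]2)cc1` gives 1000 nM. For the measured compounds named here, only one other compound has been run: compound 1 `O=C(O)c1ccccc1-c1ccc(CCc2ncc(CCc3ccccc3)[nH]2)cc1` gives 1320 nM in this assay, and the step of a 1.3-fold lower number from compound 1 to compound 2 (0.12 log units; within the scatter) lies within the scatter, so the two compounds are not separated by the numbers in hand. Compound 3 `CC(C)(C)CCc1cnc(CCc2ccc(-c3ccccc3C(=O)O)cc2)[nH]1` is not yet measured. It differs from compound 2 by neopentyl in place of cyclopropyl on a saturated chain carbon bound to an aromatic carbon. Going by the values given here, the one measured step that bears on this change is a 1.3-fold lower number from compound 1 to compound 2 (0.12 log units; within the scatter), the exchange of benzyl for cyclopropyl on the same saturated chain carbon bound to an aromatic carbon, and it did not move the number beyond the scatter. Among the compounds with values here, no measured pair covers an open branched chain at that place, so the expectation rests on that single step. The expected step of a 1.1-fold lower number from compound 2 to compound 3 (0.05 log units; within the scatter) is therefore small, and no direction beyond the scatter is claimed. Compound 3 is estimated at 900 nM in this assay, with a range from 300 nM to 3000 nM.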

Compound 3, half-maximal effective concentration: 39 nM
Estimate against measurement, compound 3: 23-fold (1.36 log units) above; the whole stated range lies above it.
By their numbers in this assay, from the lowest: compound 3; then compounds 2 and 1 (each within the scatter of the next).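

In this assay the saturated chain carbon bound to an aromatic carbon proves far from indifferent to what it carries: neopentyl in place of cyclopropyl gives a 26-fold lower number from compound 2 to compound 3 (1.41 log units; beyond the scatter), although the earlier exchange of benzyl for cyclopropyl at the same place stayed within the scatter. Cut one bond further out, tert-butyl in place of phenyl, two bonds along the chain from an aromatic carbon, gives a 34-fold lower number from compound 1 to compound 3 (1.53 log units; beyond the scatter), so among these three compounds the open branched 3,3-dimethylbutyl chain of compound 3 stands apart, while compound 1 and compound 2, which both end in a ring at this place, are not separated from each other. For the compounds shown here, nothing measured so far accounts for the gain seen with compound 3.

On these data alone, the shift rests on compound 3 alone, so it remains open whether the branched tert-butyl end is needed or whether an unbranched chain such as n-pentyl, or a shorter branched chain such as isobutyl, would give a similar number. Also open, as far as these compounds go, is whether the chain tolerates a hydroxyl or an amine at its end, or a cyclohexyl ring in place of the tert-butyl.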